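The source may hold more compounds than are shown below. What is called first, only, known or untested is meant among the compounds shown, and "the series" means these compounds.

Of the compounds shown here, three sharing one core have been measured in a functional assay on HCT-116 cells (Homo sapiens) for inhibition, read by MTT assay, with a stated time of 48 h; a lower number here means a stronger inhibitor, a higher number a weaker inhibitor. Compound 1 (`COc1ccc(N(C)c2nc(C)nc3ccccc23)cc1C(=O)OCC[Se]C#N`) gives 951 nM, and compound 2 (`COc1ccc(N(C)c2nc(C)nc3ccccc23)cc1C(=O)OCCCC[Se]C#N`) gives 662 nM. The step there is a 1.4-fold lower number from compound 1 to compound 2 (0.16 log units; within the scatter), so the two cannot be ranked. Compound 3 (`COc1ccc(N(C)c2nc(C)nc3ccccc23)cc1C[Se]C#N`), at 113 nM, has the lowest number of the three and is the strongest inhibitor among them. Compound 4 (`COc1ccc(N(C)c2nc(C)nc3ccccc23)cc1OCCCCC[Se]C#N`) departs from compound 3 by a single change: a group of 9 heavy atoms (6 carbon, 1 nitrogen, 1 oxygen, 1 selenium; no ring) in place of a group of 4 heavy atoms (2 carbon, 1 nitrogen, 1 selenium; no ring), on an aromatic carbon. The closest evidence is two measured steps, an 8.4-fold lower number from compound 1 to compound 3 (0.93 log units; beyond the scatter) and a 5.9-fold lower number from compound 2 to compound 3 (0.77 log units; beyond the scatter), in each of which a smaller group on an aromatic carbon replaces a longer one. The change to compound 4 runs in the opposite sense, so a modest rise in the number is expected in this assay. Among the measured compounds shown here, no measured compound carries the entering group, however, so this transfer is only approximate. The expected step is a 4.0-fold higher number from compound 3 to compound 4 (0.60 log units; beyond the scatter). Compound 4 is estimated at 450 nM, within an expected range from 150 nM to 1300 nM.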

Compound 4, half-maximal inhibitory concentration: 256 nM
The estimate for compound 4 lay 1.8-fold (0.24 log units) above the measured number, within the range that was stated.
By their numbers in this assay, from the lowest: compound 3; then compound 4; then compounds 2 and 1 (each within the scatter of the next).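

In this assay a long group on this aromatic carbon, ortho to a methoxy group, still raises the number, as a 2.3-fold higher number from compound 3 to compound 4 (0.36 log units; beyond the scatter) shows, but a long group need not raise it as far as the earlier ones did. The two groups containing a carbonyl fall behind compound 4 in a 2.6-fold lower number from compound 2 to compound 4 (0.41 log units; beyond the scatter) and in a 3.7-fold lower number from compound 1 to compound 4 (0.57 log units; beyond the scatter) as well, so the longer groups at this position are not interchangeable. The data shown offer no evidence for why they differ.

The compounds shown leave open whether the gain of compound 4 follows from its oxygen link or from its chain length, since these change together. A shorter chain on the same oxygen link, or an amide link in place of the carbonyl and oxygen, would separate the two.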